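Ethoxy to amino on a carbonyl carbon: compound 4

This account rests on a few compounds, and the source may have more. Where it says the series, first, only, none or still open, it means among the compounds named here.

Measured so far:
compound 1, `CCOC(=O)c1cc(CI)[nH]n1`: > 100 ug/mL (a limit)
compound 2, `NC(=O)c1cc(CI)[nH]n1`: > 100 ug/mL (a limit)
compound 3, `CCOC(=O)c1cc(CCl)nn1[C@@H]1O[C@H](COC(C)=O)[C@@H](OC(C)=O)[C@H]1OC(C)=O`: 32 ug/mL

In a functional assay on HeLa cells (Homo sapiens) (on this read-out higher numbers stand for an effect only at larger amounts of compound and lower numbers for an effect already at smaller amounts), compound 1 gives > 100 ug/mL, which is a limit of the assay and not a number. Compound 2 likewise gives > 100 ug/mL, again a limit. The change between them is amino in place of ethoxy on a carbonyl carbon, and the resulting step is a step that the two limits leave unreadable from compound 1 to compound 2; it stays unreadable because of the limit of > 100 ug/mL in this assay, at which 2 of the 3 values shown sit. Among the measured compounds shown here, compound 3 gives 32 ug/mL in this assay, the only number in the set.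

Compound 4, `CC(=O)OC[C@H]1O[C@@H](n2nc(CCl)cc2C(N)=O)[C@H](OC(C)=O)[C@@H]1OC(C)=O`, is reached from compound 3 by amino in place of ethoxy on a carbonyl carbon. The place is the same word for word as in the pair of compounds 1 and 2, so this is the same change. The difference between the core of compound 1 and the core of compound 3 is not broken down here.

Since the earlier step is unreadable, there is no measured size to carry over, and the expectation must rest on compound 3 alone. The step expected is a 1.4-fold higher number from compound 3 to compound 4 (0.15 log units; within the scatter), placed near the middle of the scatter, given that compound 3 stands at 32 ug/mL and no readable precedent argues for a direction. For compound 4 the estimate in this assay is 45 ug/mL, with a range from 15 ug/mL to 150 ug/mL.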

Compound 4, concentration for half-maximal effect: 26 ug/mL
Compound 4: middle estimate off by 1.7-fold (0.24 log units), on the high side; the measured number falls inside the stated range.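

In this assay, amino in place of ethoxy on a carbonyl carbon gives a 1.2-fold lower number from compound 3 to compound 4 (0.09 log units; within the scatter), so on the core of compound 3 the swap of ethoxycarbonyl for carbamoyl shows no readable effect on the read-out. The same change on the core of compound 1 cannot be read, and the comparison between the two cores fails at that point, because both members of that pair sit at a limit of the assay: the limit of > 100 ug/mL in this assay, at which 2 of the 4 values shown sit. The series therefore offers a single readable case of this change, which describes the core of compound 3 only and does not show whether the result carries over to the core of compound 1 or to any other core.

Still open, on these data alone, is whether a different group on the same carbonyl carbon, such as a hydroxyl giving the carboxylic acid, a methylamino or dimethylamino group giving a substituted amide, or a longer alkoxy chain such as butoxy, would move the number beyond the scatter on the core of compound 3. The cores of compound 1 and compound 3 also differ in more than one place, so the compounds shown leave open which of those differences matters in this assay.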